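A Second Chlorine on the Core, Read Across Isomers

A few compounds are considered here, and "the series" means these few. Any claim that something is new, unique, unknown or untested is made for them only; others in the source may bear on it.

Compound 1 `ClCc1ccccc1Cn1cnc2c(Cl)nc(Cl)nc21` and compound 2 `ClCc1ccccc1Cn1cnc2c(Cl)ncnc21` differ in one place: chloro in place of hydrogen on an aromatic carbon. In a functional assay on HCT-116 cells (Homo sapiens) for cytotoxicity, read by sulforhodamine B assay, with a stated time of 48 h (on this read-out higher numbers stand for lower toxicity in this test and lower numbers for higher toxicity in this test), compound 2 gives 7080 nM, while compound 1 gives 750 nM, which amounts to a 9.4-fold lower number from compound 2 to compound 1 (0.97 log units; beyond the scatter). Compound 3 `ClCc1cccc(Cn2cnc3c(Cl)ncnc32)c1` holds the same atoms as compound 2, joined differently; the difference between the two cores is not broken down here. In this assay compound 3 gives 6310 nM. Compound 4 `ClCc1cccc(Cn2cnc3c(Cl)nc(Cl)nc32)c1` differs from compound 3 by chloro in place of hydrogen on an aromatic carbon, the same change as between compound 2 and compound 1, and the surroundings of the place are described in identical words. Compound 4 is expected to show a 7.9-fold lower number from compound 3 to compound 4 (0.90 log units; beyond the scatter), resting on a 9.4-fold lower number from compound 2 to compound 1 (0.97 log units; beyond the scatter). Compound 4 is estimated at 800 nM, between 350 nM and 2000 nM.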

Compound 4, concentration lethal to 50% of the cells: 5880 nM
For compound 4 the middle estimate is 7.4-fold (0.87 log units) below the measured one, and the stated range ends below it.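

In this assay, chloro in place of hydrogen on the aromatic carbon gives a 1.1-fold lower number from compound 3 to compound 4 (0.03 log units; within the scatter), so the step seen on the first core does not reappear on the second. The change therefore does not carry over in size from one core to the other, even though the surroundings of the place read the same: the same change on two cores in this assay, a 9.4-fold lower number (0.97 log units; beyond the scatter) from compound 2 to compound 1 and a 1.1-fold lower number (0.03 log units; within the scatter) from compound 3 to compound 4, 8.8-fold (0.94 log units) apart, beyond the scatter of two such steps

Within the data shown here, this shows that the step cannot be assumed to transfer between these two cores, but it rests on only two pairs and does not show why they part.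

From the compounds shown here alone, whether an amine or a bromo group on the aromatic carbon between two ring nitrogen atoms would split the two cores in the same way remains open. So does how either core would respond with a hydroxymethyl group in place of the chloromethyl group.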